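The source may report more compounds than this note shows. Statements on the series, on what has been measured and on what is new or still open speak of the compounds shown alone.

Measured in a physicochemical assay for lipophilicity; on this read-out lower numbers stand for lower lipophilicity and higher numbers for higher lipophilicity
compound 1 `Cc1cc(C(=O)N[C@H]2CC[C@@H](NC(=O)c3cc(F)cnc3Oc3cccc(-c4cccc(CN5C[C@@H](C)N[C@@H](C)C5)c4O)c3)CC2)nn1C` gives 2.8
compound 2 `Cc1cc(C(=O)N[C@H]2CC[C@@H](NC(=O)c3cc(F)cnc3Oc3cccc(-c4ccc(CN5C[C@@H](C)N[C@@H](C)C5)cc4)c3)CC2)nn1C` gives 2.4

Of the two measured compounds, compound 2 has the lower number, and its gap to compound 1 is larger than the usual scatter of repeat measurements. Among the compounds with values here, no two measured compounds differ in just one place, so the data offer no single-change step to lean on.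

Compound 3 `C[C@@H]1CN(Cc2ccc(-c3cccc(Oc4ncc(F)cc4C(=O)N[C@H]4CC[C@@H](NC(=O)c5cc6ccccn6n5)CC4)c3)cc2)C[C@H](C)N1` has not been measured yet. It keeps the rest of compound 2 and changes one group on a carbonyl carbon (a group of 9 heavy atoms (7 carbon, 2 nitrogen; one five-membered aromatic ring with 2 hetero atoms, one six-membered aromatic ring with 1 hetero atom) in place of a group of 7 heavy atoms (5 carbon, 2 nitrogen; one five-membered aromatic ring with 2 hetero atoms), on a carbonyl carbon). The 1,5-dimethyl-1H-pyrazol-3-yl group leaves. The group that enters is larger: it also has a five-membered aromatic ring with 2 hetero atoms, and it adds a six-membered aromatic ring with 1 hetero atom. The extra heavy atoms are all carbon, and the hydrogen-bond counts stay the same. On that basis, a moderate rise beyond the scatter is expected in this assay (a number 0.50 log units higher from compound 2 to compound 3 (beyond the scatter)). For compound 3 the estimate is 2.9 (expected range 2.4 to 3.4).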

Compound 3, distribution coefficient: 2.7
Compound 3: middle estimate off by 0.20 log units, on the high side; low and high end bracket the measured number.
By their numbers in this assay, from the lowest: compounds 2, 3 and 1 (each within the scatter of the next, the first and the last beyond it).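

In this assay, within the data shown here, the swap of the 1,5-dimethyl-1H-pyrazol-3-yl group for the larger group, which keeps a five-membered aromatic ring with 2 hetero atoms and adds a six-membered aromatic ring with 1 hetero atom, gives a number 0.30 log units higher from compound 2 to compound 3 (within the scatter) and this is the only step in the set that changes just one place. For this position, on a carbonyl carbon whose other neighbour is an amide-type nitrogen, the added ring and its extra carbon atoms therefore produce no difference that this read-out can separate from the scatter of repeat measurements. No measured information is available to explain this outcome.

A single step cannot show whether the same swap would behave alike on a different core, such as the core of compound 1. From the compounds shown here alone, how other groups at this carbonyl carbon would read also remains open, for example a plain phenyl ring, a pyrazole carrying a primary amine, or a ring carrying a carboxylic acid.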